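Replacing a Methylimidazole by Benzofuran in a Cytotoxic Series

The compounds below may be only part of what the source reports. "The series", "measured", "known", "first", "only" and "open" are said of these compounds alone.

The account concerns a small set of compounds sharing one core and differing only in the group set on a double-bonded chain carbon bound to an aromatic carbon. Among the compounds with values here, compound 1 `Cc1[nH]cnc1/C=c1\[nH]c(=O)/c(=C/c2cccc(Oc3ccc(F)cc3)c2)[nH]c1=O` is the only member for which a number was obtained: in a functional assay on NCI-H460 cells (Homo sapiens) for cytotoxicity, read by MTT assay, with a stated time of 72 h (a lower number here means a stronger inhibitor, a higher number a weaker inhibitor), compound 1 gives 47.6 nM. Compound 2 `O=c1[nH]/c(=C\c2cccc(Oc3ccc(F)cc3)c2)c(=O)[nH]/c1=C\c1cccnc1` reaches only the limit of the assay, > 1000 nM. Compound 3 `O=c1[nH]/c(=C\c2ncc[nH]2)c(=O)[nH]/c1=C\c1cccc(Oc2ccc(F)cc2)c1` likewise stops at the limit, > 1000 nM. Both steps are large: an at least 21-fold higher number from compound 1 to compound 2 (1.32 log units; beyond the scatter), and an at least 21-fold higher number from compound 1 to compound 3 (1.32 log units; beyond the scatter), with the limit of > 1000 nM in this assay, at which 2 of the 3 values shown sit, marking where the two weaker members sit. The step from compound 2 to compound 3 is a step that the two limits leave unreadable from compound 2 to compound 3.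

Compound 4 `O=c1[nH]/c(=C\c2cc3ccccc3o2)c(=O)[nH]/c1=C\c1cccc(Oc2ccc(F)cc2)c1` has not yet been measured. It differs from compound 1 by 1-benzofuran-2-yl in place of 5-methyl-1H-imidazol-4-yl on a double-bonded chain carbon bound to an aromatic carbon. The two measured changes at this position, toward pyridin-3-yl and toward 1H-imidazol-2-yl, each cost heavily, so a loss is expected in this assay here as well, with a fair chance that only a limit is reported. Compound 4 is estimated at 600 nM, within a range of 100 nM to 3000 nM, which would correspond to an expected step of a 13-fold higher number from compound 1 to compound 4 (1.10 log units; beyond the scatter).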

Compound 4, half-maximal inhibitory concentration: 347 nM
The estimate for compound 4 lay 1.7-fold (0.24 log units) above the measured number; the range from low to high includes it.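

In this assay, the place on the double-bonded chain carbon bound to an aromatic carbon turns out to accept a group other than 5-methyl-1H-imidazol-4-yl and still give a readable number, at a cost of a 7.3-fold higher number from compound 1 to compound 4 (0.86 log units; beyond the scatter). The entering 1-benzofuran-2-yl has 0 hydrogen-bond donors, so a donor in this group is not needed for a readable number, though compound 1, which has one, remains ahead. The earlier replacements gave no such ordering, and compound 4 now stands ahead of both, with an at least 2.8-fold lower number from compound 3 to compound 4 (0.45 log units; beyond the scatter) and an at least 2.8-fold lower number from compound 2 to compound 4 (0.45 log units; beyond the scatter), each a lower bound on the step: the limit of > 1000 nM in this assay, at which 2 of the 4 values shown sit.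

As far as these compounds go, how a plain furan-2-yl or a 1H-indol-2-yl group would fare at this place stays open, and either would help separate the share of the six-membered ring from that of the ring oxygen. Also open, from the compounds shown here alone, is whether a methyl group on the 1H-imidazol-2-yl ring would restore the standing of compound 1.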